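A few compounds are considered here, and "the series" means these few. Any claim that something is new, unique, unknown or untested is made for them only; others in the source may bear on it.

Measured in a functional assay on NCI-H460 cells (Homo sapiens) for inhibition, with a stated time of 48 h; on this read-out lower numbers stand for stronger inhibition of growth and higher numbers for weaker inhibition of growth:
Compound 1 `COc1ccccc1/C=C/C(=O)c1c(O)cc2occc2c1OC`: > 100000 nM
Compound 2 `COc1c(C(=O)/C=C/c2ccc(Cl)cc2)c(O)c(Br)c2occc12`: 2990 nM
Compound 3 `C=CCc1c(O)c(C(=O)/C=C/c2ccccc2)c(OC)c2ccoc12`: 2790 nM

Compound 1 shows the entry > 100000 nM, which is a limit of the assay and not a number. That leaves two numbers to compare. Compound 3 gives 2790 nM and compound 2 gives 2990 nM, so the two stand within the scatter of each other.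

Compound 4 `C=CCc1c(O)c(C(=O)/C=C/c2ccc(Cl)cc2)c(OC)c2ccoc12` departs from compound 3 by a single change, chloro in place of hydrogen on an aromatic carbon, or phenyl to 4-chlorophenyl: chloro in place of hydrogen on an aromatic carbon. Among the compounds with values here, no measured pair of compounds isolates this change, so the expectation rests on little. Compound 2, which also carries a 4-chlorophenyl, gives 2990 nM, and this offers no reason to expect a large shift. In this assay the expected result is a 1.1-fold lower number from compound 3 to compound 4 (0.05 log units; within the scatter), a step estimated to stay within the scatter. The estimated value for compound 4 is 2500 nM, with an expected range from 900 nM to 7000 nM.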

Compound 4, concentration for 50% growth inhibition: 3200 nM
Beside the measured number, compound 4's estimate is 1.3-fold (0.11 log units) below it, and the stated range covers the measured number.
By their numbers in this assay, from the lowest: compounds 3, 2 and 4 (each within the scatter of the next). At a limit, above all of these: compound 1.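

In this assay, within the data shown here, chloro in place of hydrogen, para to a large group, brings a 1.1-fold higher number from compound 3 to compound 4 (0.06 log units; within the scatter) and gives the first direct reading of this change, which shows that the position carries chloro with no shift beyond the scatter. With the 4-chlorophenyl held in place, allyl in place of bromo brings a 1.1-fold higher number from compound 2 to compound 4 (0.03 log units; within the scatter) and so also leaves the read-out within the scatter, a result the two separate values could not show before. No measurement at hand bears on why these steps stay this small.

On these data alone, it remains open whether an amine or a carboxylic acid in place of the chloro would move the number beyond the scatter. As far as these compounds go, it also remains open whether a longer chain in place of the allyl would do so.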